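Benzylamino arm: methoxy in place of diethylamino

This account rests on a few compounds, and the source may have more. Where it says the series, first, only, none or still open, it means among the compounds named here.

Measured so far:
- compound 1 `CCN1CCN(CCCn2cnc3c(N4CCN(CC)CC4)nc(NCc4ccccc4)nc32)CC1`; in an assay on HEK293 cells for antagonist activity at Toll-like receptor 9 (Homo sapiens), read by spectrophotometry (a lower number here means a stronger inhibitor, a higher number a weaker inhibitor), compound 1 gives 140 nM
- compound 2 `CCN1CCN(CCCn2cnc3c(N4CCN(CC)CC4)ncnc32)CC1`; in this assay compound 2 gives 1190 nM
- compound 3 `CCN1CCN(CCCn2cnc3c(N4CCN(CC)CC4)nc(NCc4ccc(N(CC)CC)cc4)nc32)CC1`; in this assay compound 3 gives 440 nM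

Compound 3 stands second highest of the three numbers, between compound 1 and compound 2. Compound 4 `CCN1CCN(CCCn2cnc3c(N4CCN(CC)CC4)nc(NCc4ccc(OC)cc4)nc32)CC1` differs from compound 3 by methoxy in place of diethylamino on an aromatic carbon, so the benzylamino arm is kept and only its para group is exchanged. For the measured compounds named here, two steps bear on this arm: an 8.5-fold higher number from compound 1 to compound 2 (0.93 log units; beyond the scatter) and a 3.1-fold higher number from compound 1 to compound 3 (0.50 log units; beyond the scatter). The nearer guide is the second, since compound 4 again carries a small group where compound 3 carries diethylamino and compound 1 carries hydrogen. Compound 4 is therefore expected to fall between compound 1 and compound 3, the step of a 2.0-fold lower number from compound 3 to compound 4 (0.30 log units; within the scatter) being a modest lowering. The estimate for compound 4 is 220 nM, with a range from 100 nM to 480 nM.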

Compound 4, half-maximal inhibitory concentration: 200 nM
Estimate against measurement, compound 4: 1.1-fold (0.04 log units) above; measured number inside the range.
By their numbers in this assay, from the lowest: compounds 1 and 4 (each within the scatter of the next); then compound 3; then compound 2.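

Methoxy at this position on the aromatic ring reverses much of the rise seen with diethylamino (a 2.2-fold lower number from compound 3 to compound 4 (0.34 log units; beyond the scatter)), so not every group placed here carries that penalty. Methoxy and hydrogen here cannot be told apart (a 1.4-fold higher number from compound 1 to compound 4 (0.15 log units; within the scatter)). The (4-methoxybenzyl)amino arm still stands well clear of the compound that lacks the arm (a 6.0-fold lower number from compound 2 to compound 4 (0.77 log units; beyond the scatter)), so this substituted arm retains the gain.

Going by these compounds, whether a dimethylamino group, a hydroxyl or a carboxylic acid here would track methoxy or diethylamino remains open. Nothing at hand accounts for the gap between methoxy and diethylamino.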